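Replacing the thiourea at the ring nitrogen with a dichlorophenyl urea

The compounds below may be only part of what the source reports. "The series", "measured", "known", "first", "only" and "open" are said of these compounds alone.

Measured compounds:
compound 1 `NC(=O)c1c(NC(=O)c2ccccc2Cl)sc2c1CCN(Cc1ccccc1)C2` 38400 nM
compound 2 `NC(=O)c1c(NC(=O)c2ccccc2Cl)sc2c1CCN(Cc1ccc([N+](=O)[O-])cc1)C2` 46100 nM
compound 3 `COc1ccc(NC(=S)N2CCc3c(sc(NC(=O)c4ccccc4Cl)c3C(N)=O)C2)cc1` 36400 nM

All three numbers come from a functional assay on HeLa cells (Homo sapiens) for antiproliferative activity, with a stated time of 24 h; a lower number here means a stronger inhibitor, a higher number a weaker inhibitor. Compound 3 gives the lowest number of the three in this assay, but both of its gaps lie within the scatter (a 1.1-fold lower number from compound 1 to compound 3 (0.02 log units; within the scatter); a 1.3-fold lower number from compound 2 to compound 3 (0.10 log units; within the scatter)), so the three compounds cannot be told apart.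

Compound 4 `NC(=O)c1c(NC(=O)c2ccccc2Cl)sc2c1CCN(C(=O)Nc1c(Cl)cccc1Cl)C2` is not yet measured. It differs from compound 3 by a group of 11 heavy atoms (7 carbon, 1 nitrogen, 1 oxygen, 2 chlorine; one six-membered aromatic ring of carbon only) in place of a group of 11 heavy atoms (8 carbon, 1 nitrogen, 1 oxygen, 1 sulfur; one six-membered aromatic ring of carbon only), on an amine nitrogen in a ring.

For the measured compounds named here, no measured step covers this particular exchange. What the three steps do show is that changing the group on that ring nitrogen — a benzyl, a nitro-substituted benzyl, or the thiourea of compound 3 — left this assay unmoved: a 1.2-fold higher number from compound 1 to compound 2 (0.08 log units; within the scatter), a 1.1-fold lower number from compound 1 to compound 3 (0.02 log units; within the scatter) and a 1.3-fold lower number from compound 2 to compound 3 (0.10 log units; within the scatter) are all within the scatter. On that basis the expectation for compound 4 is a step of about a 1.0-fold higher number from compound 3 to compound 4 (0.02 log units; within the scatter), that is, none beyond the scatter.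

Compound 4 is therefore estimated at 38000 nM in this assay, with a range from 14000 nM to 100000 nM.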

Compound 4, half-maximal inhibitory concentration: 27200 nM
Compound 4: middle estimate off by 1.4-fold (0.15 log units), on the high side, within the range that was stated.
By their numbers in this assay, from the lowest: compounds 4, 3, 1 and 2 (each within the scatter of the next).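

Until now the amine nitrogen in a ring carried only benzyl, 4-nitrobenzyl or the sulfur-containing group of compound 3, and (2,6-dichlorophenyl)carbamoyl widens that set while leaving this assay just as unmoved: the exchange gives a 1.3-fold lower number from compound 3 to compound 4 (0.13 log units; within the scatter), and the comparisons with the benzyl compounds give a 1.4-fold lower number from compound 1 to compound 4 (0.15 log units; within the scatter) and a 1.7-fold lower number from compound 2 to compound 4 (0.23 log units; within the scatter). Even the largest of these steps stays within the scatter, so four quite different groups at this position give numbers that cannot be told apart, and the flat picture seen with the first compounds now also holds for a chlorine-bearing group in place of a sulfur-bearing one. No measurement shown here accounts for this lack of response.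

The compounds shown leave open whether a group of another kind on this nitrogen, such as a chain ending in an amine or a carboxylic acid, or a plain hydrogen, would move the number beyond the scatter. They also leave open whether changes elsewhere on the shared core would do so, since all four compounds keep the rest of that core unchanged.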